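Amide nitrogen methylation carried from one core to another

The source may hold more compounds than are shown below. What is called first, only, known or untested is meant among the compounds shown, and "the series" means these compounds.

Compound 1 `Cc1ccc(-n2nccn2)c(C(=O)N[C@@H](C)Cn2ccc(-c3ccc(F)cn3)n2)c1` is the reference point of the set. In a functional assay on cells for antagonist activity at Orexin/Hypocretin receptor type 1 (Homo sapiens), read by fluorescence and calcium flux, with a stated time of 30 min (a lower number here means a stronger inhibitor, a higher number a weaker inhibitor), compound 1 gives 10.1 nM. Compound 3 `Cc1ccc(-n2nccn2)c(C(=O)N(C)[C@@H](C)Cn2ccc(-c3ccc(F)cn3)n2)c1` differs from it only by methyl in place of hydrogen on an amide-type nitrogen. In this assay compound 3 gives 1.9 nM, which amounts to a 5.3-fold lower number from compound 1 to compound 3 (0.73 log units; beyond the scatter). Compound 2 `Cc1ccc(-n2nccn2)c(C(=O)N[C@@H](C)Cn2cc(-c3ccc(F)cn3)cn2)c1` has the same atoms as compound 1 joined differently; the difference between the two cores is not broken down here. In this assay compound 2 gives 245 nM, the highest number among the three measured. Compound 4 `Cc1ccc(-n2nccn2)c(C(=O)N(C)[C@@H](C)Cn2cc(-c3ccc(F)cn3)cn2)c1` has not been measured and stands to compound 2 as compound 3 stands to compound 1: the change is methyl in place of hydrogen on an amide-type nitrogen, and the place is described in the same words in both cases, so it is the same change. For compound 4 in this assay the expected step is a 4.9-fold lower number from compound 2 to compound 4 (0.69 log units; beyond the scatter), resting on a 5.3-fold lower number from compound 1 to compound 3 (0.73 log units; beyond the scatter). As far as these compounds go, whether the second core carries the change to the same extent is untested, so the range is kept wide. Compound 4 is therefore expected at 50 nM, with a likely span from 15 nM to 160 nM.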

Compound 4, half-maximal inhibitory concentration: 4.39 nM
For compound 4 the middle estimate is 11-fold (1.06 log units) above the measured one, and the stated range ends above it.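

In this assay, methyl in place of hydrogen on an amide-type nitrogen gives a 56-fold lower number from compound 2 to compound 4 (1.75 log units; beyond the scatter), so the direction of the step seen on the core of compound 1 also holds on the core of compound 2. The size of the step does not carry over between the two cores: the same change on two cores in this assay, a 5.3-fold lower number (0.73 log units; beyond the scatter) from compound 1 to compound 3 and a 56-fold lower number (1.75 log units; beyond the scatter) from compound 2 to compound 4, 10-fold (1.02 log units) apart, beyond the scatter of two such steps

These two pairs show that the direction held on both cores, and that the size of the step on one core did not fix its size on the other; they do not show why the step differs, or how the change would behave on any further core.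

Still open, as far as these compounds go, is whether ethyl or a longer chain on the same amide-type nitrogen would give steps that also differ between the two cores. Also open, from the compounds shown here alone, is whether the gap between the steps would persist if the fluorine were replaced by a nitrile or an amine on both cores.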